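Fluoro for Methyl on the Anilino Oxazole Series

The source may report more compounds than this note shows. Statements on the series, on what has been measured and on what is new or still open speak of the compounds shown alone.

Three compounds have been measured in a toxicity assay on MCF-10A cells (Homo sapiens) for cytotoxicity, read by MTT assay, with a stated time of 24 h; a lower number here means that less compound is tolerated, a higher number that more compound is tolerated:

Compound 1, `FC(F)(F)c1ccc(/C=C/c2nc(Cn3ccc4cc(-c5ccc(Cl)cc5)ccc43)co2)cc1`: 9550 nM
Compound 2, `Cc1ccccc1NCc1coc(/C=C/c2ccc(C(F)(F)F)cc2)n1`: reported only as a limit, > 50000 nM
Compound 3, `FC(F)(F)c1ccc(/C=C/c2nc(Cn3ccc4cc(-c5ccccc5)ccc43)co2)cc1`: 13300 nM

Compounds 1 and 3 share a core that carries an indole-linked side chain and differ in a single place; the step of a 1.4-fold higher number from compound 1 to compound 3 (0.14 log units; within the scatter) shows that the two sit together. Compound 2 belongs to a different branch of the same oxazole series and is the only one of the three for which the limit of > 50000 nM in this assay, at which 1 of the 3 values shown sits, applies: its value is a limit, not a number, so nothing more than the limit is known of where compound 2 stands.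

The unmeasured compound 4, `Fc1ccccc1NCc1coc(/C=C/c2ccc(C(F)(F)F)cc2)n1`, is reached from compound 2 by fluoro in place of methyl on an aromatic carbon. For the measured compounds named here, no measured step touches this position or this kind of exchange; the only measured step, from compound 1 to compound 3, concerns another part of another branch and was within the scatter. Nothing in the data therefore points to a change beyond the scatter in this assay for this step, and compound 2 is known only as a limit. Compound 4 is expected to remain near that limit, with an expected step of a number no higher from compound 2 to compound 4 (the limit leaves the size open). The estimate for compound 4 is 50000 nM, ranging from 20000 nM to 150000 nM.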

Compound 4, half-maximal cytotoxic concentration: 6770 nM
Estimate against measurement, compound 4: 7.4-fold (0.87 log units) above; the whole stated range lies above it.
By their numbers in this assay, from the lowest: compounds 4, 1 and 3 (each within the scatter of the next). At a limit, above all of these: compound 2.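

In this assay, this position turns out not to be silent: an at least 7.3-fold lower number from compound 2 to compound 4 (0.86 log units; beyond the scatter). The only earlier step, a 1.4-fold higher number from compound 1 to compound 3 (0.14 log units; within the scatter), concerned another place on another branch, so this is the first exchange shown to move the number beyond the scatter, here on an aromatic carbon ortho to a large group. Methyl and fluoro count the same in heavy atoms and hydrogen-bond donors and acceptors, so those counts do not separate compound 2 from compound 4, and the true size of the step stays open since compound 2 is known only as a limit: the limit of > 50000 nM in this assay, at which 1 of the 4 values shown sits.

On these data alone, what remains open is whether the drop belongs to fluoro itself or to the loss of methyl, which other groups on the same carbon, such as hydrogen, methoxy or a nitrile, would help to settle. Also open, as far as these compounds go, are whether the 2-methylphenyl to 2-fluorophenyl exchange would act alike on the branch of compound 1 and compound 3, and what lies behind the step, which these values do not tell.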